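Same atoms, joined differently: from compound 3 to compound 4

The source may hold more compounds than are shown below. What is called first, only, known or untested is meant among the compounds shown, and "the series" means these compounds.

The series is read in an ADME assay on HepG2 cells (Homo sapiens) for inhibition, with a stated time of 48 h; a higher number here means that more compound is needed for the effect, a lower number that less compound is needed. Compound 1 (`CCN(CC)C(=O)C(C)N1CCN(S(=O)(=O)c2ccc(C(C)(C)C)cc2)CC1`) gives > 40000 nM, which is a limit and not a number. Compound 2 (`CC(C(=O)N1CCc2ccccc2C1)N1CCN(S(=O)(=O)c2ccc(C(C)(C)C)cc2)CC1`) gives a true number, 29000 nM. Compound 3 (`CC(C(=O)N1CCc2cccnc2C1)N1CCN(S(=O)(=O)c2ccc(C(C)(C)C)cc2)CC1`) gives > 40000 nM, which is again a limit. Compound 3 therefore stands with compound 1 at the limit of > 40000 nM in this assay, at which 2 of the 3 values shown sit.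

Compound 4 (`CC(C(=O)N1CCc2ncccc2C1)N1CCN(S(=O)(=O)c2ccc(C(C)(C)C)cc2)CC1`) has the same atoms as compound 3, joined differently, and the change lies on a carbonyl carbon: a group of 10 heavy atoms (8 carbon, 2 nitrogen; one six-membered non-aromatic ring with 1 hetero atom, one six-membered aromatic ring with 1 hetero atom) in place of a group of 10 heavy atoms (8 carbon, 2 nitrogen; one six-membered non-aromatic ring with 1 hetero atom, one six-membered aromatic ring with 1 hetero atom), on a carbonyl carbon.

For the measured compounds named here, three measured steps bear on this change. The closest is an at least 1.3-fold higher number from compound 2 to compound 3 (0.13 log units; that floor lies within the scatter), where the group on the carbonyl carbon also changes while keeping its count of heavy atoms. The other two replace diethylamino or a group of 5 heavy atoms: an at least 1.3-fold lower number from compound 1 to compound 2 (0.13 log units; that floor lies within the scatter) and a step that the two limits leave unreadable from compound 1 to compound 3. None of these steps can be read as lying beyond the scatter, so no step beyond the scatter is expected in this assay, in either direction.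

The expected change is a number no higher from compound 3 to compound 4 (the limit leaves the size open). For compound 4 the estimated value is 40000 nM, with an expected range of 20000 nM to 80000 nM, and a limit rather than a number may well be reported.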

Compound 4, half-maximal effective concentration: > 40000 nM
Compound 4 gave a limit, no number; the forecaster's own chance of this, stated with the estimate: 60%; the middle value sits exactly at the limit.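

Compound 4 carries on the carbonyl carbon a group with the same atoms as the group in compound 3, joined differently, and in this assay it too gives a limit, not a number. For the compounds shown here, its one readable step is an at least 1.3-fold higher number from compound 2 to compound 4 (0.13 log units; that floor lies within the scatter), so compound 2 is still the only compound with a true number, and no step beyond the scatter has appeared; the steps from compound 3 to compound 4 and from compound 1 to compound 4 cannot be read, with limits at both ends. What this result adds is that both ways of joining these atoms end at the same limit, so the measurement now gives little room to tell these compounds apart: the limit of > 40000 nM in this assay, at which 3 of the 4 values shown sit.

From the compounds shown here alone, how far compound 3 and compound 4 lie from each other or from compound 2 stays open, and so does any order among them. Also open, going by these compounds, is whether an amine or a carboxylic acid on the aromatic ring of this group would give a true number in this assay and so allow a comparison with compound 2.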